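The compounds below may be only part of what the source reports. "The series", "measured", "known", "first", "only" and "open" are said of these compounds alone.

Compound 1 `CNCc1cccc(-c2ccccc2OC)c1` gives 226 nM in an assay on HEK293 cells for displacement of a labelled ligand from 5-hydroxytryptamine receptor 7 (Homo sapiens), read by scintillation counting, with a stated time of 1.5 h, in the absence of a further agent; on this read-out lower numbers stand for stronger inhibition and higher numbers for weaker inhibition.
Compound 2 `CNCc1ccc(C)c(-c2ccccc2OC)c1` gives 15 nM.
Compound 3 `COc1ccccc1-c1cc(CN2CCC(C)CC2)ccc1OC` gives 3060 nM.

Compound 3 stands at the highest number of the three, beyond the scatter from both compound 1 and compound 2, so it is the weakest of the measured compounds in this assay. Compound 4 `CNCc1ccc(OC)c(-c2ccccc2OC)c1` differs from compound 3 in one place: methylamino in place of 4-methylpiperidin-1-yl on a saturated chain carbon bound to an aromatic carbon. Among the measured compounds shown here, no measured step covers that exchange of amine directly. For the measured compounds named here, the only measured step, a 15-fold lower number from compound 1 to compound 2 (1.18 log units; beyond the scatter), concerns the substituent on the ring and not the amine, so it bears on the comparison only indirectly; both compound 1 and compound 2 carry the methylamino group that enters in compound 4, and both give much lower numbers than compound 3, which carries the 4-methylpiperidinyl group together with a methoxy substituent. On that basis, the change is expected to bring a large step downwards in this assay, a 61-fold lower number from compound 3 to compound 4 (1.79 log units; beyond the scatter). Compound 4 is therefore estimated at 50 nM, with a range from 10 nM to 250 nM.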

Compound 4, inhibition constant: 648 nM
Estimate against measurement, compound 4: 13-fold (1.11 log units) below; the whole stated range lies below it.
By their numbers in this assay, from the lowest: compound 2; then compound 1; then compound 4; then compound 3.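

Methoxy in place of methyl on an aromatic carbon brings a 43-fold higher number from compound 2 to compound 4 (1.64 log units; beyond the scatter) in this assay, and methoxy in place of hydrogen on that same carbon brings a 2.9-fold higher number from compound 1 to compound 4 (0.46 log units; beyond the scatter) at this position. Set beside a 15-fold lower number from compound 1 to compound 2 (1.18 log units; beyond the scatter) from the earlier compounds, these steps show that methyl and methoxy move the number in opposite directions from hydrogen. With the methoxy group held fixed, methylamino in place of 4-methylpiperidin-1-yl on a saturated chain carbon bound to an aromatic carbon brings a 4.7-fold lower number from compound 3 to compound 4 (0.67 log units; beyond the scatter) as a separate, modest contribution from the amine.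

The compounds shown leave open whether the amine step keeps its size with methyl or hydrogen on the aromatic carbon, and how chloro or ethyl there, or dimethylamino on the chain carbon, would compare. Nothing at hand offers an explanation for these shifts.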